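From Carboxy to Sulfamoylmethyl on the Shared Core

The compounds below may be only part of what the source reports. "The series", "measured", "known", "first", "only" and "open" are said of these compounds alone.

Compound 1, `C#CCn1c(=N)sc2cc(OC(F)(F)F)ccc21`, and compound 2, `N=c1sc2cc(OC(F)(F)F)ccc2n1CC(=O)O`, share one core and differ only in the group on a saturated chain carbon bound to an aromatic nitrogen. In a functional assay on the whole organism with Rattus norvegicus as the target (on this read-out lower numbers stand for an effect already at smaller amounts and higher numbers for an effect only at larger amounts of compound), compound 1 gives 4 mg/kg. For compound 2 this assay reports a limit rather than a number, > 10 mg/kg. Compound 2 therefore stands at the limit of > 10 mg/kg in this assay, at which 1 of the 2 values shown sits, the weaker edge of what has been measured. For the measured compounds named here, the single measured step, an at least 2.5-fold higher number from compound 1 to compound 2 (0.39 log units; beyond the scatter), shows that the change at this chain carbon moved the effect toward larger doses.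

Compound 3, `N=c1sc2cc(OC(F)(F)F)ccc2n1CCS(N)(=O)=O`, differs from compound 2 by sulfamoylmethyl in place of carboxy on a saturated chain carbon bound to an aromatic nitrogen. Going by the values given here, no measured step covers this particular exchange; the step of an at least 2.5-fold higher number from compound 1 to compound 2 (0.39 log units; beyond the scatter) tells only that the chain position is sensitive to the group placed there, and it gives no direction for a sulfamoylmethyl group. The expected step is therefore a step that the limit leaves unreadable from compound 2 to compound 3, within the scatter, with a fair chance that this assay again reports only a limit. For compound 3 the estimate is 12 mg/kg, with a range from 4 mg/kg to 40 mg/kg.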

Compound 3, dose for half-maximal effect: 6 mg/kg
Estimate against measurement, compound 3: 2.0-fold (0.30 log units) above; the measured number falls inside the stated range.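

Compound 1 to compound 2 could have suggested that any move away from ethynyl at this chain carbon pushes the effect toward larger doses, but compound 3 shows that this does not hold for every replacement. Sulfamoylmethyl in place of ethynyl gives a 1.5-fold higher number from compound 1 to compound 3 (0.18 log units; within the scatter), so in this assay compound 1 and compound 3 cannot be told apart, even though the step to carboxy lies beyond the scatter. The exchange of carboxy for sulfamoylmethyl gives an at least 1.6-fold lower number from compound 2 to compound 3 (0.22 log units; that floor lies within the scatter), so this floor alone does not separate the two groups, and the comparison rests on a limit for compound 2 rather than a number: the limit of > 10 mg/kg in this assay, at which 1 of the 3 values shown sits.

Open, from the compounds shown here alone, is whether a methylsulfonylmethyl group or a plain amine on this chain carbon would give a result that also stays within the scatter of compound 1 and compound 3 in this assay. Also open, going by these compounds, is whether a longer chain ending in the same sulfamoyl group would hold this level of effect, or whether the distance from the core matters as much as the group itself.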